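The compounds below may be only part of what the source reports. "The series", "measured", "known", "first", "only" and "open" are said of these compounds alone.

Compound 1 `COc1cccc(Nc2nc3c(c(Oc4cccc(NC(=O)C=C(C)C)c4)n2)CSCC3)c1` carries a 3-methoxyphenyl group on the ring nitrogen, and in a functional assay on HeLa cells (Homo sapiens) for antiproliferative activity, read by MTT assay, with a stated time of 72 h (a lower number here means a stronger inhibitor, a higher number a weaker inhibitor), compound 1 gives 19100 nM. Compound 2 `COc1cccc(Nc2nc3c(c(Oc4cccc(NC(=O)/C=C/C(C)C)c4)n2)CSCC3)c1` differs from compound 1 by 3-methylbut-1-en-1-yl in place of 2-methylprop-1-en-1-yl on a carbonyl carbon. In this assay compound 2 gives > 50000 nM, which is a limit of the assay and not a number. That change produced an at least 2.6-fold higher number from compound 1 to compound 2 (0.41 log units; beyond the scatter). Compound 3 `COc1ccc(Nc2nc3c(c(Oc4cccc(NC(=O)C=C(C)C)c4)n2)CSCC3)cc1` differs from compound 1 by 4-methoxyphenyl in place of 3-methoxyphenyl on a nitrogen on an aromatic ring, and in this assay compound 3 gives 19100 nM, with no change at the digits printed from compound 1 to compound 3 (within the scatter). Compound 4 `COc1ccc(Nc2nc3c(c(Oc4cccc(NC(=O)/C=C/C(C)C)c4)n2)CSCC3)cc1` has not yet been measured; it differs from compound 3 by 3-methylbut-1-en-1-yl in place of 2-methylprop-1-en-1-yl on a carbonyl carbon, the same change that turned compound 1 into compound 2, since the surroundings of the carbonyl carbon read alike in both pairs. From compound 3 to compound 4 a step of a 3.1-fold higher number from compound 3 to compound 4 (0.50 log units; beyond the scatter) is expected, resting on compound 3 starting at 19100 nM and on the earlier step of an at least 2.6-fold higher number from compound 1 to compound 2 (0.41 log units; beyond the scatter). Compound 4 is therefore expected to give about 60000 nM in this assay. The lower end for compound 4 is estimated at 30000 nM. The upper end for compound 4 is estimated at 150000 nM. A reading reported only as the limit of > 50000 nM in this assay, at which 1 of the 3 values shown sits, would not be surprising for compound 4.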

Compound 4, half-maximal inhibitory concentration: 22900 nM
The estimate for compound 4 lay 2.6-fold (0.42 log units) above the measured number; measured number below the stated range.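

On the core of compound 3, putting 3-methylbut-1-en-1-yl in place of 2-methylprop-1-en-1-yl on the carbonyl carbon gave a 1.2-fold higher number from compound 3 to compound 4 (0.08 log units; within the scatter) in this assay, so the step beyond the scatter seen on the core of compound 1 was not repeated here, yet compound 2 stands at a limit of the assay and no difference between the two steps can be claimed: the same change on two cores in this assay, an at least 2.6-fold higher number (0.41 log units; beyond the scatter) from compound 1 to compound 2 and a 1.2-fold higher number (0.08 log units; within the scatter) from compound 3 to compound 4; the limit leaves it open whether they differ The move from 3-methoxyphenyl to 4-methoxyphenyl, read on the other pair, gave an at least 2.1-fold lower number from compound 2 to compound 4 (0.33 log units; beyond the scatter), and it leaves the same question unsettled: the same change on two cores in this assay, no change at the digits printed (within the scatter) from compound 1 to compound 3 and an at least 2.1-fold lower number (0.33 log units; beyond the scatter) from compound 2 to compound 4; the limit leaves it open whether they differ The series therefore shows that neither change gave the same printed step on both cores, but it does not show that either change truly depends on the core, nor that it carries over unchanged.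

From the compounds shown here alone, the true number of compound 2 remains open, and with it the size of both steps that start or end there: the limit of > 50000 nM in this assay, at which 1 of the 4 values shown sits. Also open is how a longer chain or a carboxylic acid in place of these groups on the carbonyl carbon would read in this assay.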